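Compound 4: swapping the oxan-2-yl ring for cyclopropyl

A few compounds are considered here, and "the series" means these few. Any claim that something is new, unique, unknown or untested is made for them only; others in the source may bear on it.

Values in a physicochemical assay for lipophilicity; on this read-out lower numbers stand for lower lipophilicity and higher numbers for higher lipophilicity:
- compound 1 `O=C1NC(=O)C(Cc2ccc(OCC3CCCCO3)cc2)S1`: 2.29
- compound 2 `O=C1NC(=O)C(Cc2ccc(OCC3CCCCC3)cc2)S1`: 3.94
- compound 3 `O=C1N=C(O)S/C1=C\c1ccc(OCC2CCCCC2)cc1`: 3.66

Compound 1 holds the lowest of the three numbers. The nearest number, from compound 3 at 3.66, lies beyond the scatter above it, and compound 2 lies furthest above.

Compound 4 `O=C1NC(=O)C(Cc2ccc(OCC3CC3)cc2)S1` is the next to be read. It carries cyclopropyl in place of oxan-2-yl on a saturated chain carbon bound to an oxygen on an aromatic ring. Cut one bond further out, this reads (oxan-2-yl)methyl to cyclopropylmethyl.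

Among the measured compounds shown here, the only measured step at this place is a number 1.65 log units higher from compound 1 to compound 2 (beyond the scatter), a large one, with cyclohexyl in place of oxan-2-yl. Compound 3 differs from compound 1 in more than one place and offers no guide. Cyclopropyl also lacks the hetero atom but is a smaller ring than cyclohexyl, so a rise well short of that large step is expected. The expected step in this assay is a number 0.41 log units higher from compound 1 to compound 4 (beyond the scatter). For compound 4 the estimated value is 2.7, with an expected range of 2.2 to 3.2.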

Compound 4, partition coefficient: 2.26
Compound 4: middle estimate off by 0.44 log units, on the high side; measured number inside the range.
By their numbers in this assay, from the lowest: compounds 4 and 1 (each within the scatter of the next); then compounds 3 and 2 (each within the scatter of the next).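

At the saturated chain carbon bound to an oxygen on an aromatic ring, cyclopropyl in place of oxan-2-yl gives a number 0.03 log units lower from compound 1 to compound 4 (within the scatter) in this assay, so the two groups cannot be told apart on this read-out, although cyclohexyl in place of oxan-2-yl gave a large step. Cyclopropyl in place of cyclohexyl gives a number 1.68 log units lower from compound 2 to compound 4 (beyond the scatter), which shows that the read-out does not follow the ring oxygen alone: the two carbon-only rings stand far apart, and one of them matches the oxygen-bearing ring. No measurement at hand accounts for this.

Still open, going by these compounds, is where cyclobutyl or cyclopentyl would fall between compound 4 and compound 2, and whether an open butyl chain or a piperidine ring would follow the same trend. Also open, on these data alone, is whether the cyclopropyl step holds on the core of compound 3.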